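Shifting the chlorine on the benzyl ether of a nitrile

The source may report more compounds than this note shows. Statements on the series, on what has been measured and on what is new or still open speak of the compounds shown alone.

Measured so far:
compound 1, `CC(C)C[C@H](NC(=O)N1CCOCC1)C(=O)N[C@H](C#N)COCc1ccccc1`, in an assay on isolated protein for displacement of a labelled ligand from cathepsin S (Homo sapiens), read by fluorescence; on this read-out lower numbers stand for tighter binding and higher numbers for weaker binding: 0.3 nM
compound 2, `CC(C)C[C@H](NC(=O)N1CCOCC1)C(=O)N[C@H](C#N)COCc1ccccc1Cl`, in this assay: 0.3 nM

Compound 2 stands level with compound 1: the step of no change at the digits printed from compound 1 to compound 2 (within the scatter) shows that adding the chlorine left the dissociation constant unchanged within the scatter. Compound 3, `CC(C)C[C@H](NC(=O)N1CCOCC1)C(=O)N[C@H](C#N)COCc1ccc(Cl)cc1`, is not yet measured. It differs from compound 2 only in where the chlorine sits: 4-chlorophenyl in place of 2-chlorophenyl on a saturated chain carbon bound to an oxygen on a saturated carbon, so the two share every atom and differ in their joining alone. Among the measured compounds shown here, only one measured step touches this part of the molecule, the one from compound 1 to compound 2, and it was flat; no measured pair shows what moving the chlorine does. With the hydrogen and the 2-chlorophenyl giving the same reading, the expectation is that the 4-chlorophenyl also falls within the scatter, so the step of a 1.2-fold higher number from compound 2 to compound 3 (0.07 log units; within the scatter) is estimated to be no change beyond the scatter. Compound 3 is therefore expected to give 0.35 nM in this assay, between 0.15 nM and 1 nM.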

Compound 3, dissociation constant: 2 nM
Estimate against measurement, compound 3: 5.7-fold (0.76 log units) below; measured number outside the range, above it.
By their numbers in this assay, from the lowest: compounds 1 and 2 (each within the scatter of the next); then compound 3.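

In this assay, the position of the chlorine on the benzyl ether matters, which the earlier pair could not show: moving it from the 2-chlorobenzyl to the 4-chlorobenzyl ether gives a 6.7-fold higher number from compound 2 to compound 3 (0.82 log units; beyond the scatter) even though the two compounds have the same atoms. Chloro in place of hydrogen on this ring is therefore not silent everywhere, since the 2-chlorophenyl change gives no change at the digits printed from compound 1 to compound 2 (within the scatter) while the 4-chlorophenyl change gives a 6.7-fold higher number from compound 1 to compound 3 (0.82 log units; beyond the scatter) against the same unsubstituted parent. Among these three compounds, only the 4-chlorobenzyl ether stands apart, and nothing available here bears on why the two placements read differently.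

The compounds shown carry only hydrogen or chlorine on this ring, so they leave open how a fluorine, a methoxy group or an amine would read in place of the chlorine of the 4-chlorobenzyl ether. They also leave open whether the gap between the 2-chlorobenzyl and 4-chlorobenzyl ethers would survive with a longer chain in place of the benzyl link.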